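Trimming the chain to the ring on the amide carbonyl

A few compounds are considered here, and "the series" means these few. Any claim that something is new, unique, unknown or untested is made for them only; others in the source may bear on it.

Within the data shown here, compound 2 `COc1cc2nc(N3CCN(C(=O)CC4CCSS4)CC3)nc(N)c2cc1OC` sits at the lower end of the two numbers so far: in a functional assay on thoracic aorta for antagonist activity at Alpha-1D adrenergic receptor (Rattus norvegicus) (a lower number here means tighter binding, a higher number weaker binding), compound 2 gives 0.912 nM, while compound 1 `COc1cc2nc(N3CCN(C(=O)CCCCC4CCSS4)CC3)nc(N)c2cc1OC` gives 12 nM. Among the measured compounds shown here, the one step between them, a 13-fold lower number from compound 1 to compound 2 (1.12 log units; beyond the scatter), came from the shorter chain between the carbonyl carbon and the five-membered ring. Compound 3 `COc1cc2nc(N3CCN(C(=O)C4CCSS4)CC3)nc(N)c2cc1OC` carries the same change one stage further: a group of 5 heavy atoms (3 carbon, 2 sulfur; one five-membered non-aromatic ring with 2 hetero atoms) in place of a group of 6 heavy atoms (4 carbon, 2 sulfur; one five-membered non-aromatic ring with 2 hetero atoms), on a carbonyl carbon, so that the ring sits directly on the carbonyl carbon whose other neighbour is the amide-type nitrogen in a ring. For the measured compounds named here, only the step from compound 1 to compound 2 bears on this; it was large and in the favourable direction, but a single step gives no assurance that the gain continues once no chain remains, and the move may equally level off or reverse. A step of a 1.3-fold lower number from compound 2 to compound 3 (0.11 log units; within the scatter) is therefore expected in this assay, modest and possibly within the scatter. Compound 3 is estimated at 0.7 nM in this assay, with a range from 0.15 nM to 3.5 nM.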

Compound 3, dissociation constant: 0.871 nM
Beside the measured number, compound 3's estimate is 1.2-fold (0.09 log units) below it; the range from low to high includes it.
By their numbers in this assay, from the lowest: compounds 3 and 2 (each within the scatter of the next); then compound 1.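

In this assay, the gain seen on shortening the chain does not carry through to the last stage: a 1.0-fold lower number from compound 2 to compound 3 (0.02 log units; within the scatter), so placing the ring on a carbonyl carbon whose other neighbour is the amide-type nitrogen in a ring leaves the number within the scatter of compound 2. The whole change still holds as a large one, a 14-fold lower number from compound 1 to compound 3 (1.14 log units; beyond the scatter), and within these three compounds the benefit of trimming is therefore settled by the stage of compound 2, with compound 3 going against any continued trend with chain length. Why the number responds to the long chain of compound 1 yet stays flat over the last trim cannot be said, as no supporting data on these compounds are at hand.

On these data alone, the ring itself stays constant throughout, so it remains open whether the sulfur atoms matter at all, a question that an all-carbon cyclopentyl ring on the carbonyl carbon would address. Also open, as far as these compounds go, is how an open-chain group on that carbon, such as a simple alkyl chain or one ending in an amine or a carboxylic acid, would compare with the five-membered ring with 2 hetero atoms.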